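The source may hold more compounds than are shown below. What is called first, only, known or untested is meant among the compounds shown, and "the series" means these compounds.

Of the compounds shown here, three that share a similar core have been tested in an ADME assay (liver) for metabolic stability, with Liver microsome (Rattus norvegicus) as the target, read by LC-MS, using microsomes, with a stated time of 30 min, tested at 4 uM; on this read-out lower numbers stand for a less stable compound and higher numbers for a more stable compound. Compound 1 `CC(=O)NCCn1c(-c2ccccc2Cl)nc2c(N3CCN(C)CC3)nc(C)nc21` gives 0%, compound 2 `CCN1CCN(c2nc(C)nc3c2nc(-c2ccccc2Cl)n3CC2CCOCC2)CC1` gives 80%, and compound 3 `Cc1nc(N2CCN(C)CC2)c2nc(-c3cccc(C(F)(F)F)c3)n(C3CCOCC3)c2n1` gives 28%. This puts compound 3 in the middle of the three, above compound 1 and below compound 2, with both gaps beyond the usual scatter of repeated measurements.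

Compound 4 `Cc1nc(N2CCN(C)CC2)c2nc(-c3ccccc3F)n(C3CCOCC3)c2n1` has not yet been measured. It differs from compound 3 in one place: 2-fluorophenyl stands in place of 3-(trifluoromethyl)phenyl on an aromatic carbon, next to the ring atom that bears an oxan-4-yl group (2-fluorophenyl in place of 3-(trifluoromethyl)phenyl on an aromatic carbon).

Within the data shown here, no measured pair isolates this swap, so the best guide is compound 3 itself at 28%. Compound 1 and compound 2 each differ from compound 3 in more than one place, so their wide spread says little about this single change. A modest upward step is expected, a number 10 percentage points higher from compound 3 to compound 4 (within the scatter), and it may well not stand clear of the scatter. The uncertainty is large, so the expected range is wide. In this assay, the estimated value for compound 4 is 38%, with a range from 15% to 68%.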

Compound 4, percent of the compound remaining: 30%
Compound 4: middle estimate off by 8 percentage points, on the high side; measured number inside the range.
By their numbers in this assay, from the lowest: compound 1; then compounds 3 and 4 (each within the scatter of the next); then compound 2.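

Among these compounds, compound 3 and compound 4 form the only pair here that differs in a single place, so they give the first direct look at this position on the shared core. In this assay, putting 2-fluorophenyl in place of 3-(trifluoromethyl)phenyl gives a number 2 percentage points higher from compound 3 to compound 4 (within the scatter), which means this assay does not tell the two groups apart, even though the group that leaves has 10 heavy atoms and the group that enters has 7. No measurement shown here offers an explanation for this result, so the reason for it remains unknown.

This single swap alters both the substituent and its place on the phenyl ring, so the pair cannot show whether either alteration would matter alone, or whether two such alterations happen to offset each other. The compounds shown also leave open how a quite different group would fare at this position, such as an unsubstituted phenyl, a pyridine ring, or a phenyl ring carrying an amine or a carboxylic acid.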